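A few compounds are considered here, and "the series" means these few. Any claim that something is new, unique, unknown or untested is made for them only; others in the source may bear on it.

In a functional assay on ACHN cells (Homo sapiens) for inhibition, read by sulforhodamine B assay, with a stated time of 48 h (on this read-out higher numbers stand for weaker inhibition of growth and lower numbers for stronger inhibition of growth), compound 2, `COc1cc(-c2nn(-c3cccc(NC(=O)Nc4cc(C(F)(F)F)cc(C(F)(F)F)c4)c3)cc2-c2ccncc2)ccc1Cl`, gives 491 nM, and this is the lower of the two numbers recorded so far; compound 1, `O=C(Nc1cccc(-n2cc(-c3ccncc3)c(-c3ccc(Cl)c(O)c3)n2)c1)Nc1cccc(C(F)(F)F)c1`, gives in this assay 1290 nM, a gap that lies beyond the usual scatter. Compound 1 and compound 2 differ in more than one place, so no single step can be read from that pair.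

Compound 3, `O=C(Nc1cccc(-n2cc(-c3ccncc3)c(-c3ccc(Cl)c(O)c3)n2)c1)Nc1cc(C(F)(F)F)cc(C(F)(F)F)c1`, remains to be measured. It arises from compound 2 by hydrogen in place of methyl on an oxygen on an aromatic ring, so that compound 3 carries the 4-chloro-3-hydroxyphenyl group that compound 1 also carries. Among the compounds with values here, no measured pair isolates this one change, so its effect is unknown from the data at hand.

Compound 3 is expected to give about 650 nM in this assay, with a plausible range from 250 nM to 1600 nM. The step expected from compound 2 to compound 3, a 1.3-fold higher number from compound 2 to compound 3 (0.12 log units; within the scatter), is a modest weakening that lies within the usual scatter, because compound 1 with its hydroxy group gives 1290 nM while its other difference from compound 2 leaves the size of the methoxy-to-hydroxy effect uncertain.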

Compound 3, concentration for 50% growth inhibition: 624 nM
Beside the measured number, compound 3's estimate is 1.0-fold (0.02 log units) above it; the range from low to high includes it.
By their numbers in this assay, from the lowest: compounds 2 and 3 (each within the scatter of the next); then compound 1.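

In this assay, going from 4-chloro-3-methoxyphenyl to 4-chloro-3-hydroxyphenyl gives a 1.3-fold higher number from compound 2 to compound 3 (0.10 log units; within the scatter), so with everything else held fixed, methoxy and hydroxy on this aromatic ring cannot be told apart in this growth read-out. The second new step isolates a change elsewhere in the molecule: with the hydroxy group kept, trifluoromethyl in place of hydrogen on an aromatic carbon gives a 2.1-fold lower number from compound 1 to compound 3 (0.32 log units; beyond the scatter), a modest change but one beyond the scatter, and thus the only one of the two single changes that clearly moves the number. This separates the two differences that the pair of compound 1 and compound 2 left tangled, although nothing at hand offers an explanation for either step.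

The compounds shown leave open whether this position would tolerate an ethoxy group, a longer chain on the oxygen, or an amine in place of the hydroxy group. They also leave open whether the chlorine on the same ring contributes to the growth inhibition, and whether a fluorine or a methyl group there would give a similar number.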